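The source may report more compounds than this note shows. Statements on the series, on what has been measured and on what is new or still open speak of the compounds shown alone.

Measured compounds:
Compound 1, `CCC(=O)Oc1ccc2c(C)cc(=O)oc2c1Cc1c(C)[nH]c2ccccc12`: 31000 nM
Compound 2, `CCCOc1ccc2c(C)cc(=O)oc2c1CN1CCc2ccccc2C1`: > 100000 nM
Compound 3, `COc1ccc2c(=O)c(Cc3c(OC(C)=O)ccc4ccc(=O)oc34)c(N(C)C)oc2c1`: 26000 nM

All three were tested in an ADME assay on MT4 cells (Homo sapiens) for cytotoxicity, read by MTT assay, with a stated time of 96 h; on this read-out higher numbers stand for lower toxicity in this test and lower numbers for higher toxicity in this test. In this assay compound 1 gives 31000 nM and compound 3 gives 26000 nM; these two numbers lie within the usual scatter of each other, so neither compound can be placed above the other in toxicity. Compound 2 reached only the limit of the test, (the limit of > 100000 nM in this assay, at which 1 of the 3 values shown sits), and so has no number of its own.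

The compound not yet measured is compound 4, `CCC(=O)Oc1ccc2ccc(=O)oc2c1Cc1c(C)[nH]c2ccccc12`. Compared with compound 1 it differs in one place: hydrogen in place of methyl on an aromatic carbon. The rest of the shared core, including the ester and the indole part, stays the same.

Among the measured compounds shown here, since this change removes only a single carbon from the core, the expected step of a 1.0-fold lower number from compound 1 to compound 4 (0.01 log units; within the scatter) is none beyond the scatter. For compound 4 the estimated value in this assay is therefore 30000 nM, in a range from 12000 nM to 80000 nM.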

Compound 4, half-maximal cytotoxic concentration: 80000 nM
The estimate for compound 4 lay 2.7-fold (0.43 log units) below the measured number; low and high end bracket the measured number.
By their numbers in this assay, from the lowest: compounds 3 and 1 (each within the scatter of the next); then compound 4. At a limit, above all of these: compound 2.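

Hydrogen in place of methyl on this aromatic carbon, opposite the ring oxygen, gives a 2.6-fold higher number from compound 1 to compound 4 (0.41 log units; beyond the scatter) in this assay and so points to lower toxicity in this test. Among the compounds shown here, the earlier compounds included no pair differing in one place, so this is the first sign that this position affects the read-out, and the loss of a single carbon is enough to produce a modest step. This rests on one pair of compounds, and nothing measured here explains why the number moves.

As far as these compounds go, it remains open whether an ethyl group, a longer chain or a chlorine atom on this carbon would give a number closer to that of the methyl or the hydrogen compound. From the compounds shown here alone, it is also open whether the same change would produce a similar step if the ester were replaced by an ether or an amide.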